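Isopropyl Exchanged for Trifluoromethyl on the Aryl Group

The source may hold more compounds than are shown below. What is called first, only, known or untested is meant among the compounds shown, and "the series" means these compounds.

Of the compounds shown here, two have so far been measured in a functional assay on aorta for antagonist activity at Alpha-1D adrenergic receptor (Rattus norvegicus); a higher number here means weaker binding, a lower number tighter binding. Compound 1 `CSc1ccccc1N1CCN(CCCNc2ncccc2C(=O)N(C)C)CC1` gives 31.6 nM. Compound 2 `CC(C)c1ccccc1N1CCN(CCCNc2ncccc2C(=O)N(C)C)CC1` gives 63.1 nM, the higher of the two numbers, and the step of a 2.0-fold higher number from compound 1 to compound 2 (0.30 log units; within the scatter) lies within the scatter. Compound 3 `CN(C)C(=O)c1cccnc1NCCCN1CCN(c2ccccc2C(F)(F)F)CC1` has not yet been measured; it differs from compound 2 by trifluoromethyl in place of isopropyl on an aromatic carbon. Going by the values given here, the only measured step that bears on a change at an aromatic carbon of this ring is a 2.0-fold higher number from compound 1 to compound 2 (0.30 log units; within the scatter), which also exchanged one group for another on an aromatic carbon and stayed within the scatter. On that basis no step beyond the scatter is expected in this assay, though one small step is a thin basis and the range is kept wide. The expected step is a 1.3-fold lower number from compound 2 to compound 3 (0.10 log units; within the scatter). Compound 3 is therefore estimated at 50 nM, between 15 nM and 160 nM.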

Compound 3, dissociation constant: 316 nM
Compound 3: the middle estimate sits 6.3-fold (0.80 log units) below what was measured, and the stated range ends below it.
By their numbers in this assay, from the lowest: compounds 1 and 2 (each within the scatter of the next); then compound 3.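

In this assay this place on the aryl group proves sensitive to the group it carries: a 5.0-fold higher number from compound 2 to compound 3 (0.70 log units; beyond the scatter) is a step beyond the scatter, whereas the exchange between methylsulfanyl and isopropyl stayed within it. The step of a 10-fold higher number from compound 1 to compound 3 (1.00 log units; beyond the scatter) is also beyond the scatter, so among these three groups trifluoromethyl alone stands apart, even though its heavy-atom count is close to that of isopropyl. Nothing available here explains this separation.

Still open, from the compounds shown here alone, is whether another group at this place, such as methoxy, chlorine or an amine, would stay close to compound 1 and compound 2 or fall nearer compound 3. Going by these compounds, it also remains open whether trifluoromethyl would give a step of similar size elsewhere on the aromatic ring.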